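Phenoxy for chloro at the para position of compound 3

This account rests on a few compounds, and the source may have more. Where it says the series, first, only, none or still open, it means among the compounds named here.

Measured so far in a functional assay on DU-145 cells (Homo sapiens) for inhibition, read by trypan blue exclusion, with a stated time of 96 h; on this read-out lower numbers stand for stronger inhibition of growth and higher numbers for weaker inhibition of growth:
compound 1 `CC(=O)Oc1ccc(/C=C(\C(=O)c2ccc(Cl)cc2)S(=O)(=O)c2ccc(C)cc2)cc1` gives 25000 nM
compound 2 `Cc1ccc(S/C(=C/c2ccc(Oc3ccccc3)cc2)C(=O)c2ccc(Cl)cc2)cc1` gives 10000 nM
compound 3 `Cc1ccc(S(=O)(=O)/C(=C/c2ccc(Cl)cc2)C(=O)c2ccc(Cl)cc2)cc1` gives 1000 nM

Compound 3 stands at the lowest number of the three; compound 2 is nearest, compound 1 furthest, and both gaps lie beyond the scatter. Within the data shown here, the one single-point step recorded is a 25-fold lower number from compound 1 to compound 3 (1.40 log units; beyond the scatter), where chloro enters for acetoxy on an aromatic carbon.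

Compound 4 `Cc1ccc(S(=O)(=O)/C(=C/c2ccc(Oc3ccccc3)cc2)C(=O)c2ccc(Cl)cc2)cc1` is not yet measured. It differs from compound 3 in one place: phenoxy in place of chloro on an aromatic carbon. Among the measured compounds shown here, no measured step covers this particular exchange. Compound 2 carries the same phenoxy group but with a thioether rather than a sulfone, so its value and that of compound 3 are not a clean comparison; all that can be said is that compound 2 gives 10000 nM and compound 3 gives 1000 nM. The step from compound 1 to compound 3 shows that the group at this position can move the number a great deal, and chloro was the better of the two options seen there.

On that basis the number for compound 4 is expected to rise, by a step of about a 5.0-fold higher number from compound 3 to compound 4 (0.70 log units; beyond the scatter). The estimate for compound 4 in this assay is 5000 nM, with a range from 1500 nM to 20000 nM.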

Compound 4, concentration for 50% growth inhibition: 1000 nM
Estimate against measurement, compound 4: 5.0-fold (0.70 log units) above; measured number outside the range, below it.
By their numbers in this assay, from the lowest: compounds 3 and 4 (each within the scatter of the next); then compound 2; then compound 1.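

In this assay the exchange of chloro for phenoxy para to a large group gives no change at the digits printed from compound 3 to compound 4 (within the scatter) and so, in this pair, the number does not follow the move from one heavy atom to seven heavy atoms and a six-membered aromatic ring. With phenoxy held fixed, the thioether and sulfone forms can now be compared directly: (4-methylphenyl)sulfonyl in place of (4-methylphenyl)sulfanyl gives a 10-fold lower number from compound 2 to compound 4 (1.00 log units; beyond the scatter) and this places the high number of compound 2 with the sulfanyl group rather than with phenoxy. Phenyl in place of acetyl on the oxygen gives a 25-fold lower number from compound 1 to compound 4 (1.40 log units; beyond the scatter) in line with a 25-fold lower number from compound 1 to compound 3 (1.40 log units; beyond the scatter) so, of the three groups seen at this position, acetoxy alone goes with the high number, while chloro and phenoxy lie within the scatter of each other.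

The compounds shown leave open whether an amine or a carboxylic acid at this position would keep the number of compound 4, and whether the sulfonyl-for-sulfanyl step carries over to a compound bearing chloro. No measurement shown here bears on the reason for these steps.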